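The source may hold more compounds than are shown below. What is called first, only, known or untested is meant among the compounds shown, and "the series" means these compounds.

Of the compounds shown here, three from one series have been measured in an assay for inhibition of Fatty-acid amide hydrolase 1 (Rattus norvegicus); on this read-out higher numbers stand for weaker inhibition and lower numbers for stronger inhibition. Compound 1 `CNC(=O)c1cnc(C(=O)CCc2ccc(COc3ccccc3)cc2)o1` gives 3.6 nM. Compound 3 `N#Cc1cnc(C(=O)CCc2ccc(Oc3ccccc3)cc2)o1` gives 0.8 nM. Compound 2 `O=C(O)c1cc(-c2cnc(C(=O)CCc3ccc(-c4ccccc4)cc3)o2)ccn1` gives 50 nM, the highest of the three numbers, so it is the weakest inhibitor of the set: its gap to compound 1 and its gap to compound 3 both lie beyond the usual scatter of repeated measurements.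

Compound 4 `CN(C)C(=O)c1cnc(C(=O)CCc2ccc(-c3ccccc3)cc2)o1` has not yet been measured. It differs from compound 2 in one place: dimethylcarbamoyl in place of 2-carboxypyridin-4-yl on an aromatic carbon. Going by the values given here, no pair of measured compounds that differ in a single place is available, so the size of this step cannot be read from a direct comparison. Two observations still guide an expectation, although both compounds also differ from compound 2 elsewhere in the molecule. Compound 1, which also carries a carbamoyl group on the five-membered ring, gives 3.6 nM, and compound 3, with another small group at that place, gives 0.8 nM. Both lie well below compound 2. On this basis compound 4 is expected to be a stronger inhibitor, with the step of a 10-fold lower number from compound 2 to compound 4 (1.00 log units; beyond the scatter) expected to fall beyond the scatter. The estimate for compound 4 in this assay is 5 nM, within a range of 1 nM to 25 nM.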

Compound 4, inhibition constant: 3 nM
Beside the measured number, compound 4's estimate is 1.7-fold (0.22 log units) above it, and the stated range covers the measured number.
By their numbers in this assay, from the lowest: compound 3; then compounds 4 and 1 (each within the scatter of the next); then compound 2.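

In this assay, going by these compounds alone, the change at this position gives a 17-fold lower number from compound 2 to compound 4 (1.22 log units; beyond the scatter), the first direct comparison in the set between compounds that differ in only one place. It shows that the aromatic carbon next to the ring oxygen is sensitive to the group it carries, and that stronger inhibition does not need a ring there: dimethylcarbamoyl has no ring, fewer heavy atoms and no hydrogen-bond donor, yet it gives the lower number. Nothing measured here explains why the number falls by this much.

This single step changes several things at once, so the compounds shown cannot tell whether the loss of the six-membered aromatic ring, the loss of the carboxyl group, or the arrival of the dimethylcarbamoyl group accounts for the difference. A plain pyridin-4-yl group without the carboxyl, or a carboxylic acid attached directly to this carbon with the rest of compound 4 unchanged, would help to pull these contributions apart.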